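The source may report more compounds than this note shows. Statements on the series, on what has been measured and on what is new or still open speak of the compounds shown alone.

Measured compounds in this series:

Compound 1 `O=C(NCc1ccc(F)cc1)c1nc(Br)c2cccnc2c1NCc1ccc(F)cc1` gives > 20000 nM in a functional assay on MDA-MB-435 cells (Homo sapiens) for cytotoxicity, read by MTT assay, with a stated time of 72 h (a higher number here means a weaker inhibitor, a lower number a stronger inhibitor), which is a limit of the assay rather than a number.
Compound 2 `COc1cccc(CNC(=O)c2nc(Br)c3cccnc3c2N[C@H]2CC[C@H](N)CC2)c1` gives 7000 nM in this assay.
Compound 3 `O=CNCCCCCCNc1nc(C(=O)NCc2ccc(F)cc2)c(O)c2ncccc12` gives 16000 nM in this assay.

Among the numbers shown, compound 2 holds the lowest value; the nearest other number is that of compound 3, and the gap between the two lies beyond the usual scatter of this assay. Compound 1 contributes only a limit, so its position relative to the others cannot be fixed beyond that. No single-change step between measured compounds is available in this set, so any expectation for a new analogue rests on the compounds shown and on the structural change alone.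

Compound 4 `N[C@H]1CC[C@H](Nc2c(C(=O)NCc3cccs3)nc(Br)c3cccnc23)CC1` is the next analogue to be measured. It differs from compound 2 by one change: thiophen-2-yl in place of 3-methoxyphenyl on a saturated chain carbon bound to an amide-type nitrogen. The remainder of the structure, including the core of compound 2 and the amine substituent on the core, is unchanged.

For the measured compounds named here, with no comparable step measured in this assay, the change from compound 2 to compound 4 is expected to produce no shift beyond the scatter, with a weak drift towards a higher number allowed for. The step of a 1.3-fold higher number from compound 2 to compound 4 (0.11 log units; within the scatter) is therefore estimated to be small. Compound 4 is expected to give 9000 nM in this assay, within a range from 3500 nM to 20000 nM.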

Compound 4, half-maximal inhibitory concentration: 4100 nM
For compound 4 the middle estimate is 2.2-fold (0.34 log units) above the measured one, and the stated range covers the measured number.
By their numbers in this assay, from the lowest: compounds 4 and 2 (each within the scatter of the next); then compound 3. At a limit, above all of these: compound 1.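

Working notes on the series: in this assay, the step of a 1.7-fold lower number from compound 2 to compound 4 (0.23 log units; within the scatter) is the first single-change reading in this series, and it falls at the saturated chain carbon bound to an amide-type nitrogen. For the compounds shown here, at this place, 3-methoxyphenyl, with 8 heavy atoms and a six-membered aromatic ring of carbon only, can give way to thiophen-2-yl, with 5 heavy atoms and a five-membered aromatic ring with 1 hetero atom, without a shift beyond the scatter; the earlier compounds offered no such pair. No measurement shown bears on why this step stays so small, so the result records only its size.

From the compounds shown here alone, whether this place tolerates change more widely stays open: a non-aromatic group such as cyclohexyl, a longer chain such as 2-phenylethyl, or a carboxylic acid on the aromatic ring could move the value in either direction. Compounds 1 and 3 differ from compounds 2 and 4 in more than one place, so those steps cannot be read, and the share of the amine substituent on the core remains unresolved.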